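The source may report more compounds than this note shows. Statements on the series, on what has been measured and on what is new or still open speak of the compounds shown alone.

Measured compounds:
Compound 1 `Oc1nnc(-c2ccccc2)c2cncn12` — in a functional assay for inhibition, with Homo sapiens as the target (on this read-out lower numbers stand for stronger inhibition and higher numbers for weaker inhibition), compound 1 gives 19000 nM.
Compound 2 `CSc1nnc(-c2ccccc2)c2cncn12` — in this assay compound 2 gives only a limit, > 48000 nM.
Compound 3 `CCCc1ncc2cnnc(SC)n12` — in this assay compound 3 gives only a limit, > 48000 nM.

Compounds 1 and 2 share a core and differ in one place: hydroxy in place of methylsulfanyl on an aromatic carbon. That change brings an at least 2.5-fold lower number from compound 2 to compound 1 (0.40 log units; beyond the scatter); the size of the step is bounded because the limit of > 48000 nM in this assay, at which 2 of the 3 values shown sit, is where compound 2 sits. Compound 4 `CCCc1ncc2cnnc(O)n12` has not yet been measured. It stands to compound 3 as compound 1 stands to compound 2: hydroxy in place of methylsulfanyl on an aromatic carbon. The two cores differ, but that difference is not broken down here. Going by the values given here, the change is therefore the same kind of change, not the same: in compound 2 the place is also para to a group of 6 heavy atoms, which has no counterpart in compound 3. For compound 4 in this assay a step of an at least 1.9-fold lower number from compound 3 to compound 4 (0.28 log units; that floor lies within the scatter) is expected, resting on the earlier step of an at least 2.5-fold lower number from compound 2 to compound 1 (0.40 log units; beyond the scatter). Compound 3 sits at the same limit as compound 2, so the starting point is uncertain. The estimate for compound 4 is 25000 nM, expected to lie between 8000 nM and 80000 nM.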

Compound 4, half-maximal inhibitory concentration: > 48000 nM
Compound 4: only a limit was reported (the forecaster's own chance of this, stated with the estimate: 40%); at least 1.9-fold (0.28 log units) between middle value and limit.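

Going by these compounds alone, compound 3 and compound 4 both give only a limit, and it is the same one, so no step between them can be read: the limit of > 48000 nM in this assay, at which 3 of the 4 values shown sit. The compounds shown leave open whether hydroxy in place of methylsulfanyl lowers the number on the core of compound 3, as it does on the core of compound 1.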